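One Methyl Step, Measured Once, Expected Again

This account rests on a few compounds, and the source may have more. Where it says the series, first, only, none or still open, it means among the compounds named here.

Three compounds built on one shared core were tested in a functional assay on HepG2 cells (Homo sapiens) for cytotoxicity, read by MTT assay, with a stated time of 72 h; a higher number here means a weaker inhibitor, a lower number a stronger inhibitor. Compound 2 `COc1ccc2ccc(=O)oc2c1C(/C=C/c1ccccc1)=N/NC(N)=O` gives 82 nM. Compound 1 `COc1ccc2ccc(=O)oc2c1C(/C=C/c1ccc(C)cc1)=N/NC(N)=O` gives 93 nM. The change from compound 2 to compound 1 is methyl in place of hydrogen on an aromatic carbon, and it made a 1.1-fold higher number from compound 2 to compound 1 (0.05 log units; within the scatter).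

Compound 3 `COc1ccc2ccc(=O)oc2c1C1=NN(C(N)=O)C(c2ccccc2)C1` carries a core whose difference from that of compound 2 is not broken down here; in this assay compound 3 gives 90 nM, a number that lies within the scatter of both compound 1 and compound 2.

Compound 4 `COc1ccc2ccc(=O)oc2c1C1=NN(C(N)=O)C(c2ccc(C)cc2)C1` has not yet been measured. It differs from compound 3 by methyl in place of hydrogen on an aromatic carbon, the same change as that from compound 2 to compound 1, at the same place. For the measured compounds named here, the step from compound 3 to compound 4 is estimated at a 1.1-fold higher number from compound 3 to compound 4 (0.02 log units; within the scatter), because the one earlier example of this change gave a 1.1-fold higher number from compound 2 to compound 1 (0.05 log units; within the scatter). Compound 4 is therefore expected to give about 95 nM in this assay, most likely between 50 nM and 190 nM.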

Compound 4, half-maximal inhibitory concentration: 46 nM
The estimate for compound 4 lay 2.1-fold (0.31 log units) above the measured number; measured number below the stated range.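

In this assay, the change from phenyl to 4-methylphenyl on the core of compound 3 gave a 2.0-fold lower number from compound 3 to compound 4 (0.29 log units; within the scatter). Set beside the earlier step on the other core, this shows that the change carried across without a gap that the measurements can separate: the same change on two cores in this assay, a 1.1-fold higher number (0.05 log units; within the scatter) from compound 2 to compound 1 and a 2.0-fold lower number (0.29 log units; within the scatter) from compound 3 to compound 4, 2.2-fold (0.35 log units) apart, within the scatter of two such steps. It does not show that the two cores respond alike, for a single step on each core is too little to fix the size of the change on either one, and neither step establishes an effect of the methyl group at all.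

The compounds shown leave open how either core would respond to another group at this place on the ring, such as a chlorine atom, a methoxy group or an amine. They also leave open whether a longer chain such as ethyl, or a carboxylic acid, would give steps that stand clear of the scatter and differ between the two cores.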